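Fluoro in place of hydroxy: compound 3 to compound 4

The source may hold more compounds than are shown below. What is called first, only, known or untested is meant among the compounds shown, and "the series" means these compounds.

Compound 1 `CC1=C(/C=C/C(C)=C/C=C/C(C)=C\C(=O)NCc2cccc(F)c2)C(C)(C)CCC1n1ccnc1`: 1650 nM
Compound 2 `CC1=C(/C=C/C(C)=C/C=C/C(C)=C\C(=O)Nc2cccc(F)c2)C(C)(C)CCC1n1ccnc1`: 8510 nM
Compound 3 `CC1=C(/C=C/C(C)=C/C=C/C(C)=C\C(=O)NCc2ccc(O)cc2)C(C)(C)CCC1n1ccnc1`: 2230 nM

In a functional assay on MDA-MB-231 cells (Homo sapiens) for inhibition, read by MTT assay (on this read-out lower numbers stand for stronger inhibition of growth and higher numbers for weaker inhibition of growth), compound 3 gives 2230 nM, level within the scatter with compound 1 and clearly apart from compound 2. Compound 4 `CC1=C(/C=C/C(C)=C/C=C/C(C)=C\C(=O)NCc2ccc(F)cc2)C(C)(C)CCC1n1ccnc1` differs by fluoro in place of hydroxy on an aromatic carbon. The closest evidence is a 1.4-fold higher number from compound 1 to compound 3 (0.13 log units; within the scatter), a change of ring substituent on the benzyl amide that stays within the scatter. The larger 5.2-fold higher number from compound 1 to compound 2 (0.71 log units; beyond the scatter) and a 3.8-fold lower number from compound 2 to compound 3 (0.58 log units; beyond the scatter) both involve the loss or return of the chain carbon, which is not touched here. The expected 1.2-fold lower number from compound 3 to compound 4 (0.07 log units; within the scatter) therefore lies within the scatter. For compound 4 the estimated value is 1900 nM, with an expected range of 850 nM to 4200 nM.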

Compound 4, concentration for 50% growth inhibition: 1410 nM
Beside the measured number, compound 4's estimate is 1.3-fold (0.13 log units) above it; low and high end bracket the measured number.
By their numbers in this assay, from the lowest: compounds 4, 1 and 3 (each within the scatter of the next); then compound 2.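

In this assay, fluoro in place of hydroxy on this aromatic carbon gives a 1.6-fold lower number from compound 3 to compound 4 (0.20 log units; within the scatter), so the hydrogen-bond donor and acceptor of hydroxy can leave without a step beyond the scatter. With 4-fluorophenyl in place of 3-fluorophenyl on the chain carbon, a 1.2-fold lower number from compound 1 to compound 4 (0.07 log units; within the scatter) also stays within the scatter, whereas 4-fluorobenzyl in place of 3-fluorophenyl on the amide-type nitrogen gives a 6.0-fold lower number from compound 2 to compound 4 (0.78 log units; beyond the scatter), again with the chain carbon present in the lower-numbered compound. Nothing measured here explains these steps. As far as these compounds go, whether an amine or a carboxylic acid at this ring position would hold the number in the same range remains open.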